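Series notes: alkyl versus anilino on the imine nitrogen

A few compounds are considered here, and "the series" means these few. Any claim that something is new, unique, unknown or untested is made for them only; others in the source may bear on it.

For the measured compounds named here, compound 2 `C/C(=N\Nc1ccccc1)c1c(O)c2ccccc2oc1=O` is the only member of the set with a number rather than a limit. In an assay on isolated protein for inhibition of myosin-2 (Bos taurus), read by spectrophotometry, with a stated time of 24 min (a higher number here means a weaker inhibitor, a lower number a stronger inhibitor), compound 2 gives 27000 nM. Compound 1 `CCC/N=C(\C)c1c(O)c2ccccc2[nH]c1=O` sits at a limit of this assay, >= 100000 nM. Compound 3 `C/C(=N\CC1CCCCC1)c1c(O)c2ccccc2[nH]c1=O` likewise sits at a limit, >= 100000 nM. Two of the three results shown therefore lie at the limit of >= 100000 nM in this assay, at which 2 of the 3 values shown sit, and the one step between measured compounds, a step that the two limits leave unreadable from compound 1 to compound 3, cannot be read for size.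

Compound 4 `C/C(=N\C(C)C)c1c(O)c2ccccc2oc1=O` is to be measured in this assay. It differs from compound 2 by isopropyl in place of anilino on a double-bonded nitrogen. Going by the values given here, no measured pair spans this change: compound 1 and compound 3 carry alkyl groups on the double-bonded nitrogen but share a different core with each other than compound 2 and compound 4 do, and their step is unreadable. What can be said is that the alkyl-bearing compounds 1 and 3 both returned limits, whereas the anilino-bearing compound 2 returned a number.

On that basis a step toward weaker inhibition is expected, a 3.0-fold higher number from compound 2 to compound 4 (0.47 log units; beyond the scatter), with a real chance that only a limit is reported. Compound 4 is estimated at 80000 nM, with a range from 20000 nM to 300000 nM.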

Compound 4, half-maximal inhibitory concentration: >= 100000 nM
Compound 4 ended at the assay's limit; the forecaster's own chance of this, stated with the estimate: 50%; middle value at least 1.2-fold (0.09 log units) from the limit.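

Within the shared core of compound 2 and compound 4, in this assay, isopropyl in place of anilino on a double-bonded nitrogen gives an at least 3.7-fold higher number from compound 2 to compound 4 (0.56 log units; beyond the scatter), the first step in the series whose size can be read at all. The earlier contrast between alkyl and anilino ran across different cores, whereas this pair differs in one place only, so the loss of inhibition belongs to this change at this position, with the anilino ring and its hydrogen-bond donor and acceptor count leaving together. Compound 4 sits at a limit, so the step gives a minimum size and not a full one, and every alkyl group shown on this nitrogen has ended at the same limit: the limit of >= 100000 nM in this assay, at which 3 of the 4 values shown sit.

The pair cannot separate the aromatic ring from the linking nitrogen of anilino, and a benzyl group on the double-bonded nitrogen would keep the ring without that nitrogen. From the compounds shown here alone, the step from compound 1 to compound 3 cannot be read, and whether anilino would give a measurable number on the core of compound 1 also remains open.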